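Removing one trifluoromethyl group from compound 3

This account rests on a few compounds, and the source may have more. Where it says the series, first, only, none or still open, it means among the compounds named here.

In a functional assay on MIA PaCa-2 cells (Homo sapiens) for inhibition, read by MTT assay, with a stated time of 72 h (a higher number here means a weaker inhibitor, a lower number a stronger inhibitor), compound 3 `COc1cc(NC(C)CCCNC(=O)Nc2cc(C(F)(F)F)cc(C(F)(F)F)c2)c2ncccc2c1` gives 4700 nM and holds the lowest number of those shown. Compound 2 `COc1cc(NC(C)CCCNC(=O)Nc2cccc(O)c2)c2ncccc2c1` gives 46000 nM as its value, a higher number than that of compound 3. Compound 1 `COc1cc(NC(C)CCCNC(=O)NNC(=O)Nc2ccc(F)cc2)c2ncccc2c1` reaches only a limit of the assay at >= 250000 nM and gives no number.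

Compound 4 `COc1cc(NC(C)CCCNC(=O)Nc2cccc(C(F)(F)F)c2)c2ncccc2c1` is not yet measured. It differs from compound 3 by a single change hydrogen in place of trifluoromethyl on an aromatic carbon with hydrogen in place of trifluoromethyl on an aromatic carbon. Among the measured compounds shown here, the only measured step between two compounds differing in one place is an at least 5.4-fold lower number from compound 1 to compound 2 (0.73 log units; beyond the scatter) and it exchanges a whole group on an amide-type nitrogen, so it gives no direct size for this change. The values themselves are the closer guide. Compound 4 keeps one trifluoromethyl group, so it is expected to lie above compound 3 at 4700 nM and probably under compound 2 at 46000 nM on the same scale. A modest rise beyond the scatter is therefore expected, and the estimated change is a 2.6-fold higher number from compound 3 to compound 4 (0.41 log units; beyond the scatter) in this assay as a weaker result. For compound 4 the expected value is 12000 nM with an estimated range from 4000 nM to 35000 nM as the likely outcome.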

Compound 4, half-maximal inhibitory concentration: 17000 nM
Estimate against measurement, compound 4: 1.4-fold (0.15 log units) below, within the range that was stated.
By their numbers in this assay, from the lowest: compound 3; then compound 4; then compound 2. At a limit, above all of these: compound 1.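

In this assay, among the compounds shown here, the second trifluoromethyl group has a measurable worth of its own: its replacement by hydrogen, on an aromatic carbon meta to a trifluoromethyl group, gives a 3.6-fold higher number from compound 3 to compound 4 (0.56 log units; beyond the scatter) and so puts a size on a change at this position for the first time. The remaining trifluoromethyl group also counts when set against hydroxy, with a 2.7-fold lower number from compound 2 to compound 4 (0.43 log units; beyond the scatter), and both of these modest steps, each beyond the scatter, concern one small substituent on the aromatic ring, whereas the earlier step exchanged a whole group on the amide-type nitrogen. Compound 1 stands at a limit of the assay and not at a number, which makes an at least 14-fold lower number from compound 1 to compound 4 (1.16 log units; beyond the scatter) a bound and not a measured size: the limit of >= 250000 nM in this assay, at which 1 of the 4 values shown sits.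

On these data alone, it remains open whether other small groups at this position, such as a chlorine atom, a nitrile or a methoxy group, would fall in the same order as hydrogen, hydroxy and trifluoromethyl. Also open, as far as these compounds go, is how an amine or a carboxylic acid on this ring, or a longer chain in the linker, would shift the number.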